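This account rests on a few compounds, and the source may have more. Where it says the series, first, only, none or still open, it means among the compounds named here.

Compound 1 `Cc1ccc(-c2nn(-c3ccc(S(N)(=O)=O)cc3)cc2C(CC(=O)c2ccc(Cl)cc2)C(=O)c2ccc(F)cc2)cc1` gives 53.5% in a functional assay on the whole organism (strain Wistar albino) for inhibition, with Rattus norvegicus as the target, read by paw edema, with stated times of 1 h and 2 h, at a dose of 0.32 mmol/kg by the intraperitoneal route; a higher number here means more inhibition at the dose given (going by the name of the read-out), a lower number less inhibition. Compound 2 `COc1ccc(C(=O)C(CC(=O)c2ccc(Cl)cc2)c2cn(-c3ccc(S(N)(=O)=O)cc3)nc2-c2ccc(C)cc2)cc1` gives 53.8% in the same assay, and the step of a number 0.3 percentage points higher from compound 1 to compound 2 (within the scatter) corresponds to methoxy in place of fluoro on an aromatic carbon. Compound 3 `COc1ccc(-c2nn(-c3ccc(Cl)cc3)cc2-c2cc(-c3ccc(Cl)cc3)[nH]c2-c2ccc(F)cc2)cc1` gives 53.7%; its value and those of compounds 1 and 2 lie within the scatter of one another. The difference between the core of compound 3 and the core of compound 1 is not broken down here. Compound 4 `COc1ccc(-c2nn(-c3ccc(Cl)cc3)cc2-c2cc(-c3ccc(Cl)cc3)[nH]c2-c2ccc(OC)cc2)cc1` is not yet measured; it carries the same change as that from compound 1 to compound 2, namely (methoxy in place of fluoro on an aromatic carbon), at a place described in the same words. Because the earlier step of a number 0.3 percentage points higher from compound 1 to compound 2 (within the scatter) stayed within the scatter, compound 4 is expected to move by about a number 0.3 percentage points higher from compound 3 to compound 4 (within the scatter) from compound 3. The estimate for compound 4 in this assay is 54%, expected between 46% and 62%.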

Compound 4, a percentage reported as inhibition, in the whole organism at one dose (the size of the read-out at that dose, not a potency): 10.5%
For compound 4 the middle estimate is 43.5 percentage points above the measured one; the measured number lies below the stated range.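

In this assay, methoxy in place of fluoro on an aromatic carbon gives a number 43.2 percentage points lower from compound 3 to compound 4 (beyond the scatter) and so cannot be treated as a neutral swap across these cores. With one pair on each core, the data do not show which feature of the cores accounts for the gap, or whether the loss would recur on any other core. The step measured on one core gave no usable guide to the step on the other: the same change on two cores in this assay, a number 0.3 percentage points higher (within the scatter) from compound 1 to compound 2 and a number 43.2 percentage points lower (beyond the scatter) from compound 3 to compound 4, 43.5 percentage points apart, beyond the scatter of two such steps

On these data alone, whether the read-out at this place on the core of compound 3 depends on fluoro specifically stays open. An amine, a hydroxyl or a methyl at the same place would help separate 4-fluorophenyl from 4-methoxyphenyl.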